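Bromophenyl Replaces Trifluoromethylphenyl on a Quinazoline-Type Inhibitor Series

The compounds below may be only part of what the source reports. "The series", "measured", "known", "first", "only" and "open" are said of these compounds alone.

Measured compounds:
compound 1 `Fc1ccc(CNc2nc(-c3ccccc3C(F)(F)F)nc3ccccc23)cc1` — 3400 nM
compound 2 `FC(F)(F)c1cccc(-c2nc(NCc3ccc(-c4cccnc4)cc3)c3ccccc3n2)c1` — "not active" (no number reported)

In an assay on a protein complex for inhibition of ubiquitin carboxyl-terminal hydrolase 1/WD repeat-containing protein 48 (Homo sapiens), read by fluorescence (on this read-out lower numbers stand for stronger inhibition and higher numbers for weaker inhibition), compound 1 gives 3400 nM, whereas compound 2 is reported as "not active" (no number reported), so no number stands for compound 2 in this assay. Compound 3 `Brc1ccccc1-c1nc(NCc2ccc(-c3cccnc3)cc2)c2ccccc2n1` has not yet been measured. It differs from compound 2 in one place: 2-bromophenyl in place of 3-(trifluoromethyl)phenyl on an aromatic carbon. Among the compounds with values here, since compound 2 gives no number, no step can be sized; if any inhibition returns with compound 3, it would appear as a lower reading, but the change could also leave compound 3 without a number. Compound 3 is estimated at 6000 nM, within a range from 1500 nM to 25000 nM.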

Compound 3, half-maximal inhibitory concentration: 1600 nM
For compound 3 the middle estimate is 3.8-fold (0.57 log units) above the measured one, within the range that was stated.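

Within the data shown here, compound 2 has no number in this assay, and no step to compound 3 can be read from it. The compounds shown leave open how large the effect of exchanging 3-(trifluoromethyl)phenyl for 2-bromophenyl is, and no measurement shown accounts for the result.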